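Benzyl ether swap on the chloro analogue

A few compounds are considered here, and "the series" means these few. Any claim that something is new, unique, unknown or untested is made for them only; others in the source may bear on it.

Measured so far:
compound 1 `Cc1ccc(NC(=S)NC(=O)c2ccc(OCc3ccc(C(F)(F)F)cc3)cc2)cc1-c1nc2ccccc2[nH]1` — 72400 nM
compound 2 `Cc1ccc(NC(=S)NC(=O)c2ccc(OCc3ccc(Cl)c(Cl)c3)cc2)cc1-c1nc2ccccc2[nH]1` — 30700 nM
compound 3 `O=C(NC(=S)Nc1ccc(Cl)c(-c2nc3ccccc3[nH]2)c1)c1ccc(OCc2ccc(C(F)(F)F)cc2)cc1` — 63900 nM

In a functional assay on SW-620 cells (Homo sapiens) for inhibition, read by MTT assay, with a stated time of 48 h (a higher number here means a weaker inhibitor, a lower number a stronger inhibitor), compound 3 stands second highest of the three numbers; its gap to compound 1 is within the scatter, its gap to compound 2 beyond it. Compound 4 `O=C(NC(=S)Nc1ccc(Cl)c(-c2nc3ccccc3[nH]2)c1)c1ccc(OCc2ccc(Cl)c(Cl)c2)cc1` differs from compound 3 by 3,4-dichlorophenyl in place of 4-(trifluoromethyl)phenyl on a saturated chain carbon bound to an oxygen on an aromatic ring. The same change has been measured once, a 2.4-fold lower number from compound 1 to compound 2 (0.37 log units; beyond the scatter), on the methyl analogue, while a 1.1-fold lower number from compound 1 to compound 3 (0.05 log units; within the scatter) shows that the methyl-to-chloro change itself hardly moves the number. A modest drop in this assay is therefore expected for compound 4, roughly a 2.4-fold lower number from compound 3 to compound 4 (0.37 log units; beyond the scatter). Compound 4 is estimated at 27000 nM, with a range of 12000 nM to 60000 nM.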

Compound 4, half-maximal inhibitory concentration: 24900 nM
Compound 4: the middle estimate sits 1.1-fold (0.04 log units) above what was measured; the range from low to high includes it.
By their numbers in this assay, from the lowest: compounds 4 and 2 (each within the scatter of the next); then compounds 3 and 1 (each within the scatter of the next).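

The change from 4-(trifluoromethyl)phenyl to 3,4-dichlorophenyl now holds on a second core in this assay, giving a 2.6-fold lower number from compound 3 to compound 4 (0.41 log units; beyond the scatter), and its size carries over from the methyl analogue: the same change on two cores in this assay, a 2.4-fold lower number (0.37 log units; beyond the scatter) from compound 1 to compound 2 and a 2.6-fold lower number (0.41 log units; beyond the scatter) from compound 3 to compound 4, 1.1-fold (0.04 log units) apart, within the scatter of two such steps.
Chloro in place of methyl on an aromatic carbon also stays within the scatter with 3,4-dichlorophenyl present, giving a 1.2-fold lower number from compound 2 to compound 4 (0.09 log units; within the scatter), which matches the earlier step: the same change on two cores in this assay, a 1.1-fold lower number (0.05 log units; within the scatter) from compound 1 to compound 3 and a 1.2-fold lower number (0.09 log units; within the scatter) from compound 2 to compound 4, 1.1-fold (0.04 log units) apart, within the scatter of two such steps.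
Across these four compounds, the two changes therefore read independently of each other.

Open, going by these compounds, is whether an amine or a carboxylic acid in place of the 3,4-dichlorophenyl would move the number further.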